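The compounds below may be only part of what the source reports. "The series", "measured", "known", "first", "only" and "open" are said of these compounds alone.

In a functional assay on HCC 2998 cells (Homo sapiens) for antiproliferative activity (on this read-out lower numbers stand for stronger inhibition of growth and higher numbers for weaker inhibition of growth), compound 1 (`COc1ccc(-c2nc3cc(F)ccc3s2)cc1`) gives 12400 nM and compound 2 (`COc1ccc(-c2nc3cc(F)ccc3s2)cc1C`) gives 540 nM while compound 3 (`COc1ccc(-c2nc3cc(F)ccc3s2)cc1Cl`) gives 2500 nM and so stands between them. Compound 4 (`COc1ccc(-c2nc3cc(F)ccc3s2)cc1I`) has iodo in place of chloro on an aromatic carbon, ortho to a methoxy group (iodo in place of chloro on an aromatic carbon). Bearing on this are a 5.0-fold lower number from compound 1 to compound 3 (0.70 log units; beyond the scatter) and a 23-fold lower number from compound 1 to compound 2 (1.36 log units; beyond the scatter) along with a 4.6-fold higher number from compound 2 to compound 3 (0.67 log units; beyond the scatter) as the nearest measured steps. Within the data shown here, both replacements of hydrogen gave a lower number, yet no measured step involves iodo, so only a small step to a lower number is expected in this assay here. The expected change is a 2.1-fold lower number from compound 3 to compound 4 (0.32 log units; beyond the scatter) on this read-out. For compound 4 the estimated value is 1200 nM with an expected range from 350 nM to 4000 nM for this compound.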

Compound 4, concentration for 50% growth inhibition: 940 nM
Compound 4: middle estimate off by 1.3-fold (0.11 log units), on the high side; measured number inside the range.
By their numbers in this assay, from the lowest: compounds 2 and 4 (each within the scatter of the next); then compound 3; then compound 1.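

In this assay, iodo at this position, ortho to a methoxy group, goes further than chloro: a 2.7-fold lower number from compound 3 to compound 4 (0.42 log units; beyond the scatter). With a 13-fold lower number from compound 1 to compound 4 (1.12 log units; beyond the scatter), iodo joins methyl and chloro as a replacement of hydrogen that lowers the number, while a 1.7-fold higher number from compound 2 to compound 4 (0.24 log units; within the scatter) leaves iodo and methyl indistinguishable here. Nothing at hand gives a reason for the differences among these groups. Open, as far as these compounds go, is how an ethyl group, an amine or a carboxylic acid at this position would compare. Also open, from the compounds shown here alone, is whether the order of these groups holds on a core with the methoxy group replaced.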